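Extending the prenyl chain on two aromatic acid cores

The source may hold more compounds than are shown below. What is called first, only, known or untested is meant among the compounds shown, and "the series" means these compounds.

Measured compounds:
compound 1, `CC(C)=CCC/C(C)=C/COc1ccc(/C=C/C(=O)O)cc1O`: 12.7%
compound 2, `CC(C)=CCC/C(C)=C/CC/C(C)=C/COc1ccc(/C=C/C(=O)O)cc1O`: 16.2%
compound 3, `COc1cc(C(=O)O)ccc1OCC=C(C)C`: 2.4%

Three compounds were examined in an assay on isolated protein for inhibition of geranylgeranyl pyrophosphate synthase (Homo sapiens), tested at 100 uM; on this read-out lower numbers stand for less inhibition and higher numbers for more inhibition at the one concentration tested (going by the name of the read-out). Compound 1 has the structure `CC(C)=CCC/C(C)=C/COc1ccc(/C=C/C(=O)O)cc1O` and in this assay compound 1 gives 12.7%. Compound 2, `CC(C)=CCC/C(C)=C/CC/C(C)=C/COc1ccc(/C=C/C(=O)O)cc1O`, carries the change 3-methylbut-2-en-1-yl in place of hydrogen on a saturated chain carbon bound to a double-bonded chain carbon relative to compound 1, and in this assay compound 2 gives 16.2%. The step is a number 3.5 percentage points higher from compound 1 to compound 2 (within the scatter), so the two readings cannot be told apart. Compound 3, `COc1cc(C(=O)O)ccc1OCC=C(C)C`, rests on a different core; how that core differs from the core of compound 1 is not broken down here. In this assay compound 3 gives 2.4%, the lowest of the three numbers and beyond the scatter from both others.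

Compound 4, `COc1cc(C(=O)O)ccc1OC/C=C(\C)CCC=C(C)C`, has not yet been measured. It differs from compound 3 by 3-methylbut-2-en-1-yl in place of hydrogen on a saturated chain carbon bound to a double-bonded chain carbon, the same change as that from compound 1 to compound 2, made at the same place. Because that earlier step was a number 3.5 percentage points higher from compound 1 to compound 2 (within the scatter), a step of a similar, small size is expected from compound 3 to compound 4, namely a number 3.1 percentage points higher from compound 3 to compound 4 (within the scatter). The expectation rests on a single precedent on another core, so it is held loosely. For compound 4 the estimated value in this assay is 5.5%, expected to fall between 0% and 15%.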

Compound 4, a percentage reported as inhibition, at one concentration (the size of the read-out at that concentration, not a potency): 0%
Compound 4: middle estimate off by 5.5 percentage points, on the high side; low and high end bracket the measured number.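

In this assay, the step on the second core was a number 2.4 percentage points lower from compound 3 to compound 4 (within the scatter), so adding 3-methylbut-2-en-1-yl on a saturated chain carbon bound to a double-bonded chain carbon gave no reading that can be told apart from its parent on this core either. Set beside the step on the core of compound 1, the change gives no detectable difference between the two cores: the same change on two cores in this assay, a number 3.5 percentage points higher (within the scatter) from compound 1 to compound 2 and a number 2.4 percentage points lower (within the scatter) from compound 3 to compound 4, 5.9 percentage points apart, within the scatter of two such steps This shows only that the change produced no step beyond the scatter on either core, so the opposite directions of the two steps carry no meaning, and it does not show that the change has the same effect on both cores or that it would behave alike on any further core, since each core offers just one pair.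

The compounds shown leave open whether a longer chain than the one in compound 2 would move the reading beyond the scatter on either core. They also leave open what a phosphonic acid in place of the carboxylic acid would do, as every compound here carries the carboxylic acid and the chain changes alone have not produced a step that can be read as real.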